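Nitro for fluoro on the anilino ring of compound 1

This account rests on a few compounds, and the source may have more. Where it says the series, first, only, none or still open, it means among the compounds named here.

Compound 1 `COc1cc2c(Nc3ccc(F)cc3)ncnc2c(OC)c1OC` is the weakest-appearing member of a small set only by number, since in a functional assay on PC-3 cells (Homo sapiens) for inhibition, read by MTT assay, with a stated time of 72 h (a higher number here means a weaker inhibitor, a lower number a stronger inhibitor), compound 1 gives 24500 nM, the highest of the three values, while compound 3 `COc1cc2c(Nc3ccc(Br)cc3Cl)ncnc2c(OC)c1OC` gives 21000 nM and compound 2 `COc1cc2c(N[C@@H](C)c3ccccc3)ncnc2c(OC)c1OC` gives 10000 nM. The change from compound 1 to compound 3 was a 1.2-fold lower number from compound 1 to compound 3 (0.07 log units; within the scatter), so these two cannot be ordered; the change from compound 1 to compound 2 was a 2.5-fold lower number from compound 1 to compound 2 (0.39 log units; beyond the scatter), a modest gain, and from compound 2 to compound 3 it was a 2.1-fold higher number from compound 2 to compound 3 (0.32 log units; beyond the scatter).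

Compound 4 `COc1cc2c(Nc3ccc([N+](=O)[O-])cc3)ncnc2c(OC)c1OC` differs from compound 1 by nitro in place of fluoro on an aromatic carbon. Among the compounds with values here, the steps that bear on it are the two exchanges on the same nitrogen: the aryl-for-aryl exchange a 1.2-fold lower number from compound 1 to compound 3 (0.07 log units; within the scatter) stayed within the scatter, and only the move to a non-aryl group a 2.5-fold lower number from compound 1 to compound 2 (0.39 log units; beyond the scatter) went beyond it. An aryl-for-aryl exchange is therefore expected to give at most a small step, a 1.1-fold lower number from compound 1 to compound 4 (0.05 log units; within the scatter), with no clear direction. Compound 4 is estimated to give 22000 nM in this assay, within a range of 8000 nM to 55000 nM.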

Compound 4, half-maximal inhibitory concentration: 25500 nM
For compound 4 the middle estimate is 1.2-fold (0.06 log units) below the measured one, within the range that was stated.
By their numbers in this assay, from the lowest: compound 2; then compounds 3, 1 and 4 (each within the scatter of the next).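

In this assay, the exchange of fluoro for nitro, on an aromatic carbon para to a large group, gave a 1.0-fold higher number from compound 1 to compound 4 (0.02 log units; within the scatter), so compound 1 and compound 4 cannot be told apart. The earlier steps shown here exchanged the whole group on the nitrogen, whereas this one keeps the ring and replaces a single group on it, and here a single fluorine and the three heavy atoms of nitro, with its hydrogen-bond acceptors, give numbers within the scatter of each other. Nothing measured here offers an explanation for this result.

The compounds shown leave open whether an amine or a carboxylic acid at this same place would give a step beyond the scatter. They also leave open whether nitro would give a similarly small step on the 1-phenylethyl group of compound 2.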